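The source may hold more compounds than are shown below. What is called first, only, known or untested is meant among the compounds shown, and "the series" means these compounds.

Measured compounds:
compound 1, `C/C(=N\C(C)C)c1c(O)c2ccccc2oc1=O`; in an assay on isolated protein for inhibition of myosin-2 (Bos taurus), read by spectrophotometry, with a stated time of 24 min (on this read-out higher numbers stand for weaker inhibition and lower numbers for stronger inhibition), compound 1 gives >= 100000 nM.
compound 2, `CC/C(=N\Cc1ccccc1)c1c(O)c2ccccc2oc1=O`; in this assay compound 2 gives >= 100000 nM.

The value recorded for compound 1 is a limit of this assay and not a number. The value recorded for compound 2 is likewise a limit. Among the measured compounds shown here, compound 1 therefore stands at the limit of >= 100000 nM in this assay, at which 2 of the 2 values shown sit, and no step between the measured compounds can be sized, since neither value is a number. Compound 3, `C/C(=N\Cc1ccccn1)c1c(O)c2ccccc2oc1=O`, has not yet been measured in this assay. It differs from compound 1 in one place: (pyridin-2-yl)methyl in place of isopropyl on a double-bonded nitrogen. Both measured compounds reach only the limit, so nothing among them gives a direction for this change. In this assay the step from compound 1 to compound 3 is expected to be none beyond the scatter, with compound 3 most likely again reported only as a limit. Compound 3 is estimated at 100000 nM, with a range from 30000 nM to 300000 nM. That figure means an expected step of a number no higher from compound 1 to compound 3 (the limit leaves the size open).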

Compound 3, half-maximal inhibitory concentration: 22000 nM
Estimate against measurement, compound 3: 4.5-fold (0.66 log units) above; measured number below the stated range.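

Among the compounds shown here, on a double-bonded nitrogen, (pyridin-2-yl)methyl in place of isopropyl brings in this assay the first change that can be read, with an at least 4.5-fold lower number from compound 1 to compound 3 (0.65 log units; beyond the scatter), which lies beyond the scatter. As far as these compounds go, for compound 1 the recorded value, >= 100000 nM, is a limit and not a number, so the full size of this step stays open. Compound 3 thus gives the only number among the compounds shown, which makes this position on the nitrogen one where a change can move the read-out off the limit: the limit of >= 100000 nM in this assay, at which 2 of the 3 values shown sit.

Compound 2 carries a benzyl group but differs from compound 3 in more than one place, so the compounds shown do not tell whether the gain depends on the nitrogen of the (pyridin-2-yl)methyl ring or would come with any such ring on the core of compound 1. They also leave open how a (pyridin-3-yl)methyl group or a longer chain such as (pyridin-2-yl)ethyl would read in this assay.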